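This account rests on a few compounds, and the source may have more. Where it says the series, first, only, none or still open, it means among the compounds named here.

Compound 1, `CC[C@H]1CN(c2ncc(C(N)=O)nc2C(F)(F)F)CCN1C1CCN(C(=O)c2ccc(Cl)nc2N)CC1`, gives 1.9 nM in an in vitro assay on BaF3 cells for displacement of a labelled ligand from C-X-C chemokine receptor type 3 (Homo sapiens); on this read-out higher numbers stand for weaker inhibition and lower numbers for stronger inhibition. Compound 2, `CC[C@H]1CN(c2ncc(C(=O)NC)nc2C(F)(F)F)CCN1C1CCN(C(=O)c2ccc(Cl)nc2N)CC1`, gives 1.5 nM in this assay. Compound 3, `CC[C@H]1CN(c2ncc(C(N)=O)nc2C)CCN1C1CCN(C(=O)c2ccc(Cl)cc2)CC1`, gives 18 nM in this assay.

Compounds 1 and 2 share one core and differ in a single spot: methyl in place of hydrogen on an amide-type nitrogen. That change gives a 1.3-fold lower number from compound 1 to compound 2 (0.10 log units; within the scatter), a step the assay itself cannot tell apart from noise.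

Compound 3 sits on a different core. How its core differs from the core of compound 1 is not broken down here, so only the two numbers can be compared: compound 3 stands highest of the three measured, and its gap to compound 1 and to compound 2 lies beyond the scatter in both cases.

Compound 4, `CC[C@H]1CN(c2ncc(C(=O)NC)nc2C)CCN1C1CCN(C(=O)c2ccc(Cl)cc2)CC1`, is not yet measured. It is built from compound 3 by exactly the same change that turns compound 1 into compound 2: methyl in place of hydrogen on an amide-type nitrogen. The surroundings of the changed spot read the same in both pairs, so this is the same change on a second core.

For the measured compounds named here, the only guide to what this change does is the pair of compounds 1 and 2. Because that pair shows a 1.3-fold lower number from compound 1 to compound 2 (0.10 log units; within the scatter), compound 4 is expected to stay close to compound 3, with an estimated step of a 1.3-fold lower number from compound 3 to compound 4 (0.11 log units; within the scatter) in this assay. Compound 4 is therefore estimated at 14 nM, most likely between 7 nM and 28 nM.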

Compound 4, half-maximal inhibitory concentration: 3.6 nM
Beside the measured number, compound 4's estimate is 3.9-fold (0.59 log units) above it; measured number outside the range, below it.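

In this assay, placing a methyl on the amide nitrogen of compound 3 gives a 5.0-fold lower number from compound 3 to compound 4 (0.70 log units; beyond the scatter), so on this core the change is a step that the assay can tell apart from noise. The size of the step therefore does not carry over unchanged from one core to the other, and a result from one pair is only a rough guide to the next: the same change on two cores in this assay, a 1.3-fold lower number (0.10 log units; within the scatter) from compound 1 to compound 2 and a 5.0-fold lower number (0.70 log units; beyond the scatter) from compound 3 to compound 4, 3.9-fold (0.60 log units) apart, beyond the scatter of two such steps. For the compounds shown here, this does not show which difference between the two cores sets the size of the step, and with only two pairs it gives no rule for any further core.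

The compounds shown leave open how the two cores would have to be altered, one place at a time, for the step to shift from the small size seen on the first core to the larger one seen on the second. On these data alone, they also leave open what happens on either core when the amide nitrogen carries a longer chain, such as ethyl, or a second methyl, so it remains unknown whether the gain on the core of compound 3 is specific to methyl.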